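The compounds below may be only part of what the source reports. "The series", "measured", "known", "first", "only" and "open" are said of these compounds alone.

In a functional assay on A549 cells (Homo sapiens) for antiproliferative activity, read by MTT assay, with a stated time of 48 h (a higher number here means a weaker inhibitor, a lower number a stronger inhibitor), the series starts from compound 1, `O=C(/C=C\Nc1ccc(Cl)cc1)c1cn(-c2ccccc2)nc1-c1ccc(Cl)cc1`, which gives 3670 nM. Compound 2, `O=C(/C=C\Nc1ccc(C(F)(F)F)cc1)c1cn(-c2ccccc2)nc1-c1ccc(Cl)cc1`, differs from it by trifluoromethyl in place of chloro on an aromatic carbon. In this assay compound 2 reaches only the limit of the assay, > 50000 nM, and is not a number. The step is therefore an at least 13-fold higher number from compound 1 to compound 2 (1.13 log units; beyond the scatter), and its size is known only as a lower bound because the limit of > 50000 nM in this assay, at which 1 of the 3 values shown sits, is where compound 2 sits.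

Compound 3, `COc1ccc(-c2nn(-c3ccccc3)cc2C(=O)/C=C\Nc2ccc(Cl)cc2)cc1`, carries a different core; the two cores differ by methoxy in place of chloro on an aromatic carbon. In this assay compound 3 gives 2970 nM, and the step is a 1.2-fold lower number from compound 1 to compound 3 (0.09 log units; within the scatter), so the two cores behave alike within the measured pair.

Compound 4, `COc1ccc(-c2nn(-c3ccccc3)cc2C(=O)/C=C\Nc2ccc(C(F)(F)F)cc2)cc1`, is not yet measured. It is related to compound 3 by trifluoromethyl in place of chloro on an aromatic carbon, which is the same change that led from compound 1 to compound 2, set here on the core of compound 3; the place of the change reads the same in both pairs. Going by the values given here, the only guide for the expected outcome is the measured pair, and it rests on an at least 13-fold higher number from compound 1 to compound 2 (1.13 log units; beyond the scatter). The step from compound 3 to compound 4 is thus expected to be a 15-fold higher number from compound 3 to compound 4 (1.18 log units; beyond the scatter), with a good chance that this assay again returns only a limit rather than a number. Compound 4 is accordingly expected to come in near 45000 nM, within an estimated range from 15000 nM to 150000 nM.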

Compound 4, half-maximal inhibitory concentration: > 50000 nM
Compound 4 gave a limit, no number; the forecaster's own chance of this, stated with the estimate: 65%; middle value at least 1.1-fold (0.04 log units) from the limit.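

On the core of compound 3 the change ends the same way as on the core of compound 1: in this assay compound 4 gives > 50000 nM, which is a limit of the assay and not a number. The step is an at least 16-fold higher number from compound 3 to compound 4 (1.22 log units; beyond the scatter), so in both pairs shown, trifluoromethyl in place of chloro carries the number well upward, and this direction holds on both cores: the same change on two cores in this assay, an at least 13-fold higher number (1.13 log units; beyond the scatter) from compound 1 to compound 2 and an at least 16-fold higher number (1.22 log units; beyond the scatter) from compound 3 to compound 4; the limit leaves it open whether they differ What the two pairs do not show is whether the step has the same size on both cores, for each size is only a lower bound, and the step that joins compound 2 and compound 4 cannot be read at all, so the methoxy and chloro cores cannot be compared once trifluoromethyl is present.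

The compounds shown leave open whether any group other than chloro or trifluoromethyl on that aromatic carbon, such as fluoro, methyl or a nitrile, would stay with chloro or go with trifluoromethyl in this assay. They also leave open whether a larger or charged group there, such as an amine or a carboxylic acid, would give a number or another limit.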